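The source may report more compounds than this note shows. Statements on the series, on what has been measured and on what is new or still open speak of the compounds shown alone.

In a functional assay on KB cells (Homo sapiens) for antiproliferative activity, read by MTT assay, with a stated time of 72 h (a higher number here means a weaker inhibitor, a lower number a stronger inhibitor), the three measured compounds of this series share one core and differ only in the group carried on the methylated ring nitrogen. Compound 1 `CN(C(=O)c1ccc(Br)cc1)c1ccc2[nH]c(-c3n[nH]c4ccccc34)cc2n1` gives 1780 nM. Compound 2 `COc1cccc(C(=O)N(C)c2ccc3[nH]c(-c4n[nH]c5ccccc45)cc3n2)c1` gives 9010 nM. Compound 3 `CN(c1ccc2[nH]c(-c3n[nH]c4ccccc34)cc2n1)S(=O)(=O)c1ccccc1` gives 2400 nM. The step of a 5.1-fold higher number from compound 1 to compound 2 (0.70 log units; beyond the scatter) shows that exchanging the aryl group on the carbonyl carbon matters, whereas a 1.3-fold higher number from compound 1 to compound 3 (0.13 log units; within the scatter) shows that replacing the carbonyl by a sulfonyl does not. Against compound 2 the step of a 3.8-fold lower number from compound 2 to compound 3 (0.57 log units; beyond the scatter) is of the same size as the first one, in the opposite direction. On these numbers compound 3 stands second highest of the three, close to compound 1 and well apart from compound 2.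

Compound 4 `CN(c1ccc2[nH]c(-c3n[nH]c4ccccc34)cc2n1)S(=O)(=O)c1cccc([N+](=O)[O-])c1` is the next member. It differs from compound 3 by nitro in place of hydrogen on an aromatic carbon. For the measured compounds named here, no measured step touches a substituent on the sulfonyl phenyl; the only step that changes an aryl substituent, from compound 1 to compound 2, concerns a carbonyl aryl and was modest. The estimate for compound 4 in this assay is therefore 2200 nM, between 700 nM and 7000 nM, a step of a 1.1-fold lower number from compound 3 to compound 4 (0.04 log units; within the scatter) that is expected to stay near or within the scatter.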

Compound 4, half-maximal inhibitory concentration: 5870 nM
Estimate against measurement, compound 4: 2.7-fold (0.43 log units) below; the range from low to high includes it.
By their numbers in this assay, from the lowest: compounds 1 and 3 (each within the scatter of the next); then compounds 4 and 2 (each within the scatter of the next).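

In this assay, the sulfonyl phenyl proves sensitive to substitution: the change from phenyl to 3-nitrophenyl gives a 2.4-fold higher number from compound 3 to compound 4 (0.39 log units; beyond the scatter), a modest step but one beyond the scatter. For the compounds shown here, until now, the only measured change of an aryl substituent lay on the carbonyl side, where the exchange of 4-bromophenyl for 3-methoxyphenyl gave a 5.1-fold higher number from compound 1 to compound 2 (0.70 log units; beyond the scatter), so the number is now seen to respond to an aryl change in the sulfonyl pair as well, and in both pairs it rises. Nothing at hand accounts for the rise at this position, which stands as an observation only.

The compounds shown carry only nitro on the sulfonyl phenyl, so it stays open whether an amine or a carboxylic acid in the same place would move the number in the same direction, or by a similar amount. Going by these compounds, it is also open whether 4-bromophenyl and 3-methoxyphenyl on the sulfonyl would differ from each other as they do on the carbonyl.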